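The source may report more compounds than this note shows. Statements on the series, on what has been measured and on what is new or still open speak of the compounds shown alone.

Series notes. Among the compounds with values here, the three measured members share one core: compound 1 `COc1cccc(S(=O)(=O)c2ccc(NC(=O)C(C)(O)C(F)(F)F)cc2)c1`, compound 2 `Cc1ccc(S(=O)(=O)c2ccc(NC(=O)C(C)(O)C(F)(F)F)cc2)cc1` and compound 3 `CC(O)(C(=O)Nc1ccc(S(=O)(=O)c2ccc([N+](=O)[O-])cc2)cc1)C(F)(F)F`. In a functional assay (Cavia porcellus) with sulfonylurea receptors; K-ATP channels (Homo sapiens) as the target (a lower number here means a stronger inhibitor, a higher number a weaker inhibitor), compound 1 gives 16000 nM. For compound 2 the assay reports only a limit, > 30000 nM. For compound 3 likewise only a limit is reported, > 30000 nM. Compound 3 thus stands at the upper edge of what is seen in this series, without a number of its own, a position it shares as the limit of > 30000 nM in this assay, at which 2 of the 3 values shown sit, records. The step of an at least 1.8-fold higher number from compound 1 to compound 2 (0.27 log units; that floor lies within the scatter) and the step of an at least 1.8-fold higher number from compound 1 to compound 3 (0.27 log units; that floor lies within the scatter) both run toward weaker inhibition, each read only against a limit. The step that the two limits leave unreadable from compound 2 to compound 3 cannot be sized. Compound 4 `CC(O)(C(=O)Nc1ccc(S(=O)(=O)c2cncnc2)cc1)C(F)(F)F` differs from compound 3 by pyrimidin-5-yl in place of 4-nitrophenyl on a sulfonyl sulfur. Within the data shown here, no measured step covers this change directly; the two steps from compound 1 show that varying the group on the sulfonyl sulfur has not yet brought a number back below the limit. For compound 4 the expected change is a number no higher from compound 3 to compound 4 (the limit leaves the size open), no step beyond the scatter. Compound 4 is estimated at 30000 nM, in the range 8000 nM to 120000 nM, with a fair chance that only a limit is again reported.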

Compound 4, half-maximal inhibitory concentration: > 30000 nM
Compound 4 was reported as a limit; the forecaster's own chance of this, stated with the estimate: 60%; the middle value sits exactly at the limit.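

In this assay compound 4 also gives only a limit, > 30000 nM. On the sulfonyl sulfur, pyrimidin-5-yl, a six-membered aromatic ring with 2 hetero atoms, now joins the carbon-only rings of 4-methylphenyl and 4-nitrophenyl, so a ring of this kind has not brought a number back either, and the series gathers further at one value: the limit of > 30000 nM in this assay, at which 3 of the 4 values shown sit. The step of an at least 1.8-fold higher number from compound 1 to compound 4 (0.27 log units; that floor lies within the scatter) is read only against a limit, and the steps from compound 2 and from compound 3 to compound 4 cannot be read.

Compound 1 remains the only member with a number, 16000 nM, and the compounds shown do not tell whether that number depends on the 3-methoxyphenyl group itself. Also open, as far as these compounds go, is what an amine or a longer carbon chain on the sulfonyl sulfur would give in place of these aromatic rings.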